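Methyl in place of isopropyl on compound 3

The source may hold more compounds than are shown below. What is called first, only, known or untested is meant among the compounds shown, and "the series" means these compounds.

- Compound 1 `CC(C)c1ccc(S(C)(=O)=O)cc1C#Cc1cc(C#N)ccc1OCC(=O)O` gives 151 ng.h/mL here
- Compound 2 `COCCNS(=O)(=O)c1ccc(C)c(C#Cc2cc(Cl)ccc2OCC(=O)O)c1` gives 831 ng.h/mL here
- Compound 3 `CC(C)c1ccc(S(C)(=O)=O)cc1C#Cc1cc(Cl)ccc1OCC(=O)O` gives 2650 ng.h/mL here

In an ADME assay on the whole organism (plasma, strain BALB/c) for pharmacokinetics, with Mus musculus as the target, at a dose of 5 mg/kg by the oral route (a lower number here means less compound in the circulation, a higher number more compound in the circulation at the dose given), compound 3 stands highest of the three, and both other compounds lie lower by more than the scatter. The next structure, compound 4 `Cc1ccc(S(C)(=O)=O)cc1C#Cc1cc(Cl)ccc1OCC(=O)O`, carries methyl in place of isopropyl on an aromatic carbon, and the counted difference reads methyl in place of isopropyl on an aromatic carbon with the rest of the structure unchanged.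

For the measured compounds named here, no measured step makes this exchange. Going by the values given here, the one measured step is an 18-fold higher number from compound 1 to compound 3 (1.24 log units; beyond the scatter) and it is large, but it puts chloro in place of cyano elsewhere on the structure. Among the compounds with values here, it therefore gives no size for the present change and shows only that one exchange moved the number far between those two compounds. Compound 2 also carries a methyl where compound 3 has isopropyl, and compound 2 gives 831 ng.h/mL in this assay but differs from compound 3 elsewhere as well, so that lower value cannot be assigned to the methyl alone. It offers only a weak hint of a downward direction.

The estimated step is a 1.5-fold lower number from compound 3 to compound 4 (0.17 log units; within the scatter) with no move beyond the scatter expected. Compound 4 is expected at 1800 ng.h/mL with an estimated range from 600 ng.h/mL to 5000 ng.h/mL given how little the data constrain it.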

Compound 4, area under the concentration-time curve: 1800 ng.h/mL
Compound 4: the middle estimate sits on the measured number at the digits printed; measured number inside the range.
By their numbers in this assay, from the lowest: compound 1; then compound 2; then compounds 4 and 3 (each within the scatter of the next).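

In this assay, for the compounds shown here, the exchange of isopropyl for methyl on this aromatic carbon, para to a methylsulfonyl group, gives a 1.5-fold lower number from compound 3 to compound 4 (0.17 log units; within the scatter) and so stays inside the usual scatter, the first direct reading of this position. Compounds 3 and 4 therefore cannot be told apart here, and the size of the group at this carbon, across these two members, does not register in the read-out, unlike the exchange of chloro for cyano on the shared core. Going by these compounds alone, compound 4 also shares its methyl with compound 2, which isolates a second place for the first time: methyl in place of (2-methoxyethyl)amino on the sulfonyl sulfur gives a 2.2-fold higher number from compound 2 to compound 4 (0.34 log units; beyond the scatter) and is a modest step beyond the scatter.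

How an ethyl, a cyclopropyl or a methoxy group on this carbon would read remains open, since only methyl and isopropyl are shown there. Also open, on these data alone, is how a simple amine or a longer chain on the sulfonyl sulfur would compare, and whether the step from cyano to chloro keeps its size with methyl in place of isopropyl. Nothing among the data shown accounts for either step.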